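Chloro to trifluoromethyl on the shared core

The compounds below may be only part of what the source reports. "The series", "measured", "known", "first", "only" and "open" are said of these compounds alone.

compound 1 `Cc1ccc(N2CCCC2)c(C(=O)Nc2ccc(CNC(=O)OCc3cccnc3)cc2)c1` gives 65300 nM
compound 2 `COc1ccc(N2CCCC2)c(C(=O)Nc2ccc(CNC(=O)OCc3cccnc3)cc2)c1` gives 47200 nM
compound 3 `O=C(NCc1ccc(NC(=O)c2cc(Cl)ccc2N2CCCC2)cc1)OCc1cccnc1` gives > 100000 nM as a limit

In a functional assay on SGC-7901 cells (Homo sapiens) for inhibition, read by MTT assay, with a stated time of 72 h (on this read-out lower numbers stand for stronger inhibition and higher numbers for weaker inhibition), compound 3 gives > 100000 nM as a limit and not a number. Compound 4 `O=C(NCc1ccc(NC(=O)c2cc(C(F)(F)F)ccc2N2CCCC2)cc1)OCc1cccnc1` differs by one change, trifluoromethyl in place of chloro on an aromatic carbon on the shared core. Three measured swaps at the same aromatic carbon bear on it: a 1.4-fold lower number from compound 1 to compound 2 (0.14 log units; within the scatter) for methoxy in place of methyl, an at least 1.5-fold higher number from compound 1 to compound 3 (0.18 log units; that floor lies within the scatter) for chloro in place of methyl and an at least 2.1-fold higher number from compound 2 to compound 3 (0.32 log units; beyond the scatter) for chloro in place of methoxy. Only the last lies beyond the scatter, and it is modest as far as shown. The expected step is a number no higher from compound 3 to compound 4 (the limit leaves the size open) and no step beyond the scatter is expected in this assay here. Compound 4 is estimated at 100000 nM with a range of 45000 nM to 200000 nM and may also return only a limit.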

Compound 4, half-maximal inhibitory concentration: > 100000 nM
Compound 4 was reported as a limit; the forecaster's own chance of this, stated with the estimate: 55%; the middle value lies on the limit itself.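

In this assay, trifluoromethyl para to a pyrrolidin-1-yl group ends at the same limit as chloro, and neither compound 3 nor compound 4 returns a number: the limit of > 100000 nM in this assay, at which 2 of the 4 values shown sit.

Trifluoromethyl in place of methoxy gives an at least 2.1-fold higher number from compound 2 to compound 4 (0.32 log units; beyond the scatter), and trifluoromethyl in place of methyl gives an at least 1.5-fold higher number from compound 1 to compound 4 (0.18 log units; that floor lies within the scatter). With limits on both sides, the step between compound 3 and compound 4 cannot be read.

As far as these compounds go, whether an amine or a carboxylic acid on this aromatic carbon would give a lower number than compound 2 stays open. From the compounds shown here alone, how far compound 3 and compound 4 lie past their limit also stays open.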